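Working notes: enone-linked series, toward compound 3

The source may hold more compounds than are shown below. What is called first, only, known or untested is meant among the compounds shown, and "the series" means these compounds.

Measured so far:
compound 1 `COc1ccc(-c2cc(C(=O)/C=C/c3ccccc3)nc3cc(-c4ccccc4)nn23)cc1OC` — 18600 nM
compound 2 `COc1ccc(-c2cc(C(=O)/C=C/c3ccc(Cl)cc3)nc3cc(-c4ccccc4)nn23)cc1OC` — 22000 nM

In a functional assay on A549 cells (Homo sapiens) for antiproliferative activity, read by MTT assay, with a stated time of 24 h (on this read-out higher numbers stand for weaker inhibition and lower numbers for stronger inhibition), compound 1 gives 18600 nM and compound 2 gives 22000 nM. Going by the values given here, the one measured step, chloro in place of hydrogen on an aromatic carbon, is a 1.2-fold higher number from compound 1 to compound 2 (0.07 log units; within the scatter). Compound 2 therefore holds the highest of the two numbers, but its distance to compound 1 is within the scatter, so no order between the two can be read.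

Compound 3 `COc1ccc(-c2cc(/C=C/C(=O)c3ccc(C)cc3)nc3cc(-c4ccccc4)nn23)cc1OC` differs from compound 2 as follows: 2-((4-methylphenyl)carbonyl)ethenyl in place of (2-(4-chlorophenyl)ethenyl)carbonyl on an aromatic carbon. The group (2-(4-chlorophenyl)ethenyl)carbonyl leaves and 2-((4-methylphenyl)carbonyl)ethenyl enters, at the same place on the shared core. Among the compounds with values here, no measured step covers this change directly; the step from compound 1 to compound 2 touches only the chloro group and was within the scatter. The data thus give no ground for a step beyond the scatter in either direction in this assay.

The expected step is a 1.1-fold lower number from compound 2 to compound 3 (0.04 log units; within the scatter). Compound 3 is estimated at 20000 nM, with a range from 7000 nM to 60000 nM.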

Compound 3, half-maximal inhibitory concentration: 17200 nM
Estimate against measurement, compound 3: 1.2-fold (0.07 log units) above, within the range that was stated.
By their numbers in this assay, from the lowest: compounds 3, 1 and 2 (each within the scatter of the next).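

In this assay, this position on the aromatic carbon next to the ring nitrogen now shows a change in the linker itself, not only on its far ring, and the result stays within the scatter: a 1.3-fold lower number from compound 2 to compound 3 (0.11 log units; within the scatter), and a 1.1-fold lower number from compound 1 to compound 3 (0.03 log units; within the scatter). Against both earlier compounds, the carbonyl and the ethenyl change places in the linker while the far ring changes too, to a 4-methylphenyl end in compound 3 from a 4-chlorophenyl end in compound 2 and a plain phenyl end in compound 1, so the two changes are tied together in each step and neither can be read alone. Across these three compounds, neither the linker order nor the end group gives a step beyond the scatter, and no other data on these compounds bear on the result.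

The compounds shown keep the 3,4-dimethoxyphenyl group throughout, and each linker order appears with its own end groups, so the separate weight of the order stays open. On these data alone, whether an amine or a carboxylic acid on the far ring, or a longer chain in the linker, would give a step beyond the scatter is also open.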